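Swapping the Diethoxymethyl Group of Compound 2

The source may report more compounds than this note shows. Statements on the series, on what has been measured and on what is new or still open speak of the compounds shown alone.

Of the compounds shown here, three have been measured in an assay on 32D cells for inhibition of interleukin-15 (Mus musculus), read by resazurin assay, with stated times of 30 min and 2.5 days, in the presence of a further agent that is not named here; on this read-out higher numbers stand for weaker inhibition and lower numbers for stronger inhibition. Compound 1 `CCOC(CCn1c(Cc2nn(C)c(=O)c3ccccc23)nnc1SCC(=O)Nc1ccc(Cl)cc1Cl)OCC` and compound 3 `Cn1nc(Cc2nnc(SCC(=O)Nc3ccc(Cl)cc3Cl)n2CCC(=O)O)c2ccccc2c1=O` share their core with compound 2 `CCOC(CCn1c(Cc2nn(C)c(=O)c3ccccc23)nnc1SCCCCCCCC(=O)Nc1ccc(Cl)cc1Cl)OCC`, and of the three only compound 2 gives a number, 12100 nM. Compound 1 reaches only a limit of the assay, > 30000 nM. Compound 3 likewise stops at a limit, > 30000 nM. Among the measured compounds shown here, the one measured step, a step that the two limits leave unreadable from compound 1 to compound 3, is therefore unreadable, and the limit of > 30000 nM in this assay, at which 2 of the 3 values shown sit, is all the evidence there is on it.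

Compound 4 `Cn1nc(Cc2nnc(SCCCCCCCC(=O)Nc3ccc(Cl)cc3Cl)n2CCCO[Si](C)(C)C(C)(C)C)c2ccccc2c1=O` differs from compound 2 in one place: a group of 9 heavy atoms (7 carbon, 1 oxygen, 1 silicon; no ring) in place of a group of 7 heavy atoms (5 carbon, 2 oxygen; no ring), on a saturated chain carbon, two bonds along the chain from an aromatic nitrogen. For the measured compounds named here, no measured step bears on this change; the pair of compound 1 and compound 3 concerns a different replacement at the same place, and both of its values are limits. Nothing measured points in either direction, so a change in this assay beyond the usual scatter is not expected. Compound 4 is estimated at 12000 nM, within 4000 nM to 30000 nM, which means an expected step of a 1.0-fold lower number from compound 2 to compound 4 (0.00 log units; within the scatter).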

Compound 4, half-maximal inhibitory concentration: > 30000 nM
Compound 4 gave a limit, no number; the forecaster's own chance of this, stated with the estimate: 40%; at least 2.5-fold (0.39 log units) between middle value and limit.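

In this assay, this position, on a saturated chain carbon, two bonds along the chain from an aromatic nitrogen, now has a step that can be read: putting the group of 9 heavy atoms in place of diethoxymethyl gives an at least 2.4-fold higher number from compound 2 to compound 4 (0.39 log units; beyond the scatter). This is the first step at this place shown to lie beyond the scatter, so the measurable number of compound 2 does not persist through this replacement. From the compounds shown here alone, its full size remains unknown, because compound 4 stops at a limit of the assay rather than a number: the limit of > 30000 nM in this assay, at which 3 of the 4 values shown sit.

Going by these compounds, whether a free hydroxyl or an amine at this place would keep the number of compound 2 remains open. Also open, on these data alone, is how a carboxylic acid here would read with the longer chain of compound 2, as compound 3 carries that group only with the shorter chain.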